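Replacing 4-fluorophenyl in a growth-inhibiting series

The source may hold more compounds than are shown below. What is called first, only, known or untested is meant among the compounds shown, and "the series" means these compounds.

Values in a functional assay on HCT-116 cells (Homo sapiens) for antiproliferative activity, read by MTT assay, with a stated time of 48 h (on this read-out higher numbers stand for weaker inhibition of growth and lower numbers for stronger inhibition of growth), for the three measured compounds:
- compound 1 `Fc1ccc(C2=NN(C(=S)Nc3ccccc3)C(c3ccc4c(c3)OCCO4)C2)cc1` gives 61200 nM as a measured number
- compound 2 `S=C(Nc1ccccc1)N1N=C(c2ccc(Cl)cc2)CC1c1ccc2c(c1)OCCO2` gives > 200000 nM as a limit of the assay, not a number
- compound 3 `CSc1ccc(C2=NN(C(=S)Nc3ccccc3)C(c3ccc4c(c3)OCCO4)C2)cc1` gives 193000 nM as a measured number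

Compound 1 has the lowest number here and so the strongest growth inhibition of the three. Compound 4 `COc1ccccc1C1=NN(C(=S)Nc2ccccc2)C(c2ccc3c(c2)OCCO3)C1` keeps the core of compound 1 and changes one group: 2-methoxyphenyl in place of 4-fluorophenyl on a carbon with a double bond to nitrogen with 2-methoxyphenyl in place of 4-fluorophenyl on a carbon with a double bond to nitrogen.

For the measured compounds named here, two measured steps bear on this change. Chloro in place of fluoro gave an at least 3.2-fold higher number from compound 1 to compound 2 (0.51 log units; beyond the scatter) and methylsulfanyl in place of fluoro gave a 3.2-fold higher number from compound 1 to compound 3 (0.50 log units; beyond the scatter) as the second case, both beyond the scatter. Going by the values given here, no measured compound carries 2-methoxyphenyl, so these steps are only a guide.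

Since both moved upward, the expected result is a 2.0-fold higher number from compound 1 to compound 4 (0.29 log units; within the scatter) in this assay as a similar modest loss. Also possible for compound 4 is the limit of > 200000 nM in this assay, at which 1 of the 3 values shown sits, instead of a number. For compound 4 the estimated value is 120000 nM and the expected range runs from 45000 nM to 250000 nM in this assay.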

Compound 4, concentration for 50% growth inhibition: > 200000 nM
Compound 4 gave a limit, no number; the forecaster's own chance of this, stated with the estimate: 30%; middle value at least 1.6-fold (0.22 log units) away from the limit.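

Until now only 4-substituted phenyl groups had been shown on this carbon, and 2-methoxyphenyl extends the loss of growth inhibition to a further replacement, with an at least 3.2-fold higher number from compound 1 to compound 4 (0.51 log units; beyond the scatter). The other readable step, an at least 1.0-fold higher number from compound 3 to compound 4 (0.01 log units; that floor lies within the scatter), sets no order between those two compounds, and the step from compound 2 to compound 4 cannot be read, as both values are limits. Compound 4 joins compound 2 at a limit of the assay, leaving compound 1 clearly ahead of the other three in this assay: the limit of > 200000 nM in this assay, at which 2 of the 4 values shown sit.

As far as these compounds go, whether any group on this carbon can match or improve on 4-fluorophenyl remains open, for instance a phenyl ring bearing an amine or a carboxylic acid. Nor do these compounds separate the effect of the methoxy group from that of its place on the ring, which 4-methoxyphenyl could help to settle.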